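Isopropyl in Place of Methyl: What Compound 4 Might Give

A few compounds are considered here, and "the series" means these few. Any claim that something is new, unique, unknown or untested is made for them only; others in the source may bear on it.

Among the three compounds measured in a functional assay on K562 cells (Homo sapiens) for antiproliferative activity (on this read-out higher numbers stand for weaker inhibition and lower numbers for stronger inhibition), compound 3 `Cc1cc(NC(=O)c2ccc(C)c(Nc3nc(-c4cccnc4)cs3)c2)cc(-n2cnc(C)c2)c1` stands second highest: in this assay compound 3 gives 449 nM. Compound 1 `Cc1cn(-c2cc(NC(=O)c3ccc(C)c(Nc4nc(-c5cccnc5)cs4)c3)cc(C(F)(F)F)c2)cn1` gives 28 nM and compound 2 `Cc1ccc(C(=O)Nc2cccc(C(F)(F)F)c2)cc1Nc1nc(-c2cccnc2)cs1` gives 3010 nM, so compound 3 sits nearer to compound 2 than to compound 1. Compound 4 `Cc1cn(-c2cc(NC(=O)c3ccc(C)c(Nc4nc(-c5cccnc5)cs4)c3)cc(C(C)C)c2)cn1` differs from compound 3 by one change, (isopropyl in place of methyl on an aromatic carbon), at the aromatic carbon meta to the 4-methyl-1H-imidazol-1-yl group.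

Within the data shown here, two measured steps bear on it. The loss of the 4-methyl-1H-imidazol-1-yl group from compound 1 cost a 110-fold higher number from compound 1 to compound 2 (2.03 log units; beyond the scatter), but that step concerns another position. The closer comparison is a 16-fold higher number from compound 1 to compound 3 (1.21 log units; beyond the scatter), the exchange of trifluoromethyl for methyl at exactly the carbon where isopropyl now enters. Among the measured compounds shown here, no measured compound carries isopropyl there, so the step from compound 3 to compound 4 cannot be read off directly. Because the methyl of compound 3 accounts for a 16-fold higher number from compound 1 to compound 3 (1.21 log units; beyond the scatter) against compound 1, a three-carbon group in its place is expected to recover part, though probably not all, of that loss; the step is expected to be a 4.1-fold lower number from compound 3 to compound 4 (0.61 log units; beyond the scatter), beyond the scatter. Compound 4 is therefore estimated at 110 nM, with a range from 30 nM to 450 nM.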

Compound 4, half-maximal inhibitory concentration: 31 nM
The estimate for compound 4 lay 3.5-fold (0.55 log units) above the measured number, within the range that was stated.
By their numbers in this assay, from the lowest: compounds 1 and 4 (each within the scatter of the next); then compound 3; then compound 2.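

At this aromatic carbon, isopropyl in place of methyl gave a 14-fold lower number from compound 3 to compound 4 (1.16 log units; beyond the scatter) in this assay and so reversed nearly all of the difference that separated compound 3 from compound 1. The comparison with trifluoromethyl gave a 1.1-fold higher number from compound 1 to compound 4 (0.04 log units; within the scatter) and lies within the scatter, so on this read-out an all-carbon group at this position cannot be told apart from trifluoromethyl, and fluorine is not needed for a low number in these compounds. The data shown offer no account of why isopropyl and methyl differ so widely here.

As far as these compounds go, with only methyl, isopropyl and trifluoromethyl at this carbon, it remains open how the number would respond to ethyl, cyclopropyl, tert-butyl, a methoxy group or an amine, and therefore whether the large step from methyl to isopropyl is part of a gradual series or an abrupt one. From the compounds shown here alone, it is also open whether isopropyl would give a similar number with hydrogen in place of 4-methyl-1H-imidazol-1-yl, the change that weakened the trifluoromethyl compound so sharply.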